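The compounds below may be only part of what the source reports. "The series", "measured", "known", "first", "only" and "open" are said of these compounds alone.

In an assay on isolated protein for inhibition of RAC-beta serine/threonine-protein kinase (Homo sapiens), read by mobility shift assay, tested at 30 uM (on this read-out higher numbers stand for more inhibition at the one concentration tested (going by the name of the read-out) and lower numbers for less inhibition), three compounds have been measured. Compound 1 `CN1CCN(c2ccc(-c3cc4[nH]nc(N)c4c(=O)[nH]3)cc2)CC1` gives 6%. Compound 2 `Cc1cc2[nH]nc(N)c2c(N2CCCCC2)n1` gives 11%. Compound 3 `CC(=O)Nc1nn(C)c2cc(-c3ccccc3)[nH]c(=O)c12` gives 40%. On these numbers compound 2 sits close to compound 1, the two lying within the usual scatter of each other, while compound 3 stands apart from compound 2, its reading being the furthest away and beyond the scatter.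

The account now follows the change from compound 2 to compound 4 `Cc1cc2c(c(N)nn2C)c(N2CCCCC2)n1`. The difference is methyl in place of hydrogen on an aromatic nitrogen. The methyl enters on an aromatic nitrogen of a five-membered aromatic ring with two nitrogens, part of a fused system of two rings, next to the ring nitrogen and two ring bonds from the ring atom that bears the amino group.

Among the compounds with values here, no pair of measured compounds that differ in one place is available, so the size of this step cannot be taken from the data. Compound 3 also carries a methyl on a ring nitrogen, but it differs from compound 2 in several further places; the reading of compound 3, 40%, therefore cannot be tied to this one change. The step is therefore expected to be small, in no certain direction, and likely not beyond the scatter. Compound 4 is expected to give about 13%, with a range from 0% to 32%, which would mean an estimated step of a number 2 percentage points higher from compound 2 to compound 4 (within the scatter).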

Compound 4, a percentage reported as inhibition, at one concentration (the size of the read-out at that concentration, not a potency): 0%
Compound 4: middle estimate off by 13 percentage points, on the high side; measured number inside the range.
By their numbers in this assay, from the lowest: compounds 4, 1 and 2 (each within the scatter of the next, the first and the last beyond it); then compound 3.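

In this assay, the methyl in place of hydrogen on an aromatic nitrogen of the five-membered aromatic ring goes with a number 11 percentage points lower from compound 2 to compound 4 (beyond the scatter). Within the data shown here, this is the first change whose size can be read directly, since the earlier compounds offered no pair differing in one place, and it shows that this ring nitrogen is not indifferent to substitution on the core of compound 2. The step is modest, and with a starting reading as low as that of compound 2, it shows only that the methyl does not raise inhibition on this core at the one concentration tested; nothing given here explains the loss.

On these data alone, it remains open whether a larger group on the same nitrogen, such as an ethyl group or a longer chain ending in an amine, would behave like the methyl or restore some of the inhibition. As far as these compounds go, it is also open whether the hydrogen on this nitrogen matters in the same way on a core like that of compound 3, which gives 40% and already carries a methyl on a ring nitrogen along with an acetamide and a phenyl group.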